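Working notes: methyl in place of trifluoromethoxy

The source may hold more compounds than are shown below. What is called first, only, known or untested is meant among the compounds shown, and "the series" means these compounds.

In a functional assay on HL-60 cells (Homo sapiens) for cytotoxicity, read by WST assay, with a stated time of 48 h (on this read-out higher numbers stand for an effect only at larger amounts of compound and lower numbers for an effect already at smaller amounts), compound 1 `O=C1OC[C@H](Cc2ccccc2)[C@H]1Cc1ccccc1` gives 77000 nM, compound 2 `COc1ccc(C[C@H]2C(=O)OC[C@@H]2Cc2ccccc2)cc1` gives 67000 nM and compound 3 `O=C1OC[C@H](Cc2ccccc2)[C@H]1Cc1ccc(OC(F)(F)F)cc1` gives 27000 nM. Compound 3 holds the lowest of these three numbers, and both of its gaps lie beyond the scatter: a 2.9-fold lower number from compound 1 to compound 3 (0.46 log units; beyond the scatter) and a 2.5-fold lower number from compound 2 to compound 3 (0.39 log units; beyond the scatter).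

The next compound, compound 4 `Cc1ccc(C[C@H]2C(=O)OC[C@@H]2Cc2ccccc2)cc1`, carries methyl in place of trifluoromethoxy on an aromatic carbon, para to a large group (methyl in place of trifluoromethoxy on an aromatic carbon). Within the data shown here, no measured step leads directly to this methyl compound, so the evidence is indirect. Trifluoromethoxy is the only group here that separates itself from the others, as shown by the two modest steps above. Methoxy in place of hydrogen, by contrast, gave a 1.1-fold lower number from compound 1 to compound 2 (0.06 log units; within the scatter). On that basis, compound 4 is expected to fall back among the higher numbers, reversing a step of about the same modest size in this assay. The estimated step is a 2.2-fold higher number from compound 3 to compound 4 (0.35 log units; beyond the scatter), a rise that would only just clear the scatter. For compound 4 the estimated value is 60000 nM, with an expected range from 30000 nM to 110000 nM.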

Compound 4, half-maximal effective concentration: 44000 nM
Estimate against measurement, compound 4: 1.4-fold (0.13 log units) above, and the stated range covers the measured number.
By their numbers in this assay, from the lowest: compounds 3, 4, 2 and 1 (each within the scatter of the next, the first and the last beyond it).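

On this aromatic carbon, para to a large group, the exchange of trifluoromethoxy for methyl in this assay gives a 1.6-fold higher number from compound 3 to compound 4 (0.21 log units; within the scatter), so this change does not separate the two groups, even though methyl carries far fewer heavy atoms and no hydrogen-bond acceptor. Methyl also stays within the scatter of the other two groups at this place, with a 1.5-fold lower number from compound 2 to compound 4 (0.18 log units; within the scatter) and a 1.8-fold lower number from compound 1 to compound 4 (0.24 log units; within the scatter), which blurs the clear separation of trifluoromethoxy seen among the earlier compounds: compound 3 remains apart from compound 1 and compound 2, but compound 4 cannot be told apart from any of the three. No measured property of these groups accompanies the result, and nothing here accounts for the small differences.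

Still open, on these data alone, is whether an amine, a carboxylic acid or a longer chain such as butyl on this aromatic carbon would give a step clearly beyond the scatter in either direction. Equally open, as far as these compounds go, is whether trifluoromethoxy or methyl would give similar numbers at other places on the core of compound 1.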